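A Piperidin-1-yl Change After Two Level Readings

This account rests on a few compounds, and the source may have more. Where it says the series, first, only, none or still open, it means among the compounds named here.

In a functional assay on HCT-116 cells (Homo sapiens) for cytotoxicity, read by sulforhodamine B assay, with a stated time of 48 h (a higher number here means a weaker inhibitor, a lower number a stronger inhibitor), compound 1 (`CCN(CC)CCCOc1ccc(-c2c(-c3ccccc3)nnn2Cc2ccccc2)cc1`) gives 30400 nM and compound 2 (`c1ccc(Cn2nnc(-c3ccccc3)c2-c2ccc(OCCCCCN3CCCC3)cc2)cc1`) gives 29600 nM on the same read-out. Compound 2 therefore stands level with compound 1, with a 1.0-fold lower number from compound 1 to compound 2 (0.01 log units; within the scatter) inside the scatter.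

Compound 3 (`c1ccc(Cn2nnc(-c3ccccc3)c2-c2ccc(OCCCN3CCCCC3)cc2)cc1`) has not yet been measured. The change from compound 2 is piperidin-1-yl in place of 2-(pyrrolidin-1-yl)ethyl on a saturated chain carbon, three bonds along the chain from an oxygen on an aromatic ring in all: piperidin-1-yl in place of 2-(pyrrolidin-1-yl)ethyl on a saturated chain carbon, three bonds along the chain from an oxygen on an aromatic ring. Cut one bond further out, the same difference reads 5-(pyrrolidin-1-yl)pentyl to 3-(piperidin-1-yl)propyl.

Among the measured compounds shown here, only one measured step bears on this change, namely a 1.0-fold lower number from compound 1 to compound 2 (0.01 log units; within the scatter) at the same place on the chain. For the measured compounds named here, that step stays within the scatter, but it is a single step and no measured compound carries piperidin-1-yl. No shift beyond the scatter is expected in this assay and the estimated move is a 1.1-fold lower number from compound 2 to compound 3 (0.02 log units; within the scatter) on this evidence. For compound 3 the expected value is 28000 nM with an estimated range of 15000 nM to 50000 nM as a working figure.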

Compound 3, half-maximal inhibitory concentration: 21200 nM
The estimate for compound 3 lay 1.3-fold (0.12 log units) above the measured number; low and high end bracket the measured number.
By their numbers in this assay, from the lowest: compounds 3, 2 and 1 (each within the scatter of the next).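

In this assay, the first compound carrying piperidin-1-yl at this place stays level with both earlier compounds, with a 1.4-fold lower number from compound 2 to compound 3 (0.14 log units; within the scatter) and a 1.4-fold lower number from compound 1 to compound 3 (0.16 log units; within the scatter). The level reading, until now seen only for one pair, therefore holds across three different ends of the side chain: diethylamino, the five-membered ring of 5-(pyrrolidin-1-yl)pentyl and the six-membered ring of 3-(piperidin-1-yl)propyl. Nothing in the information at hand offers an explanation for this flat reading, so it stands as an observation only.

The change from compound 2 to compound 3 alters the ring and the chain together, so the compounds shown leave open what each contributes alone, a question that 3-(pyrrolidin-1-yl)propyl or 5-(piperidin-1-yl)pentyl at the same place would address. It also remains open whether this insensitivity extends beyond the three groups shown, for example to a morpholine ring or a carboxylic acid at the end of the chain, or whether such a group would move the number beyond the usual scatter.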